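The compounds below may be only part of what the source reports. "The series", "measured", "known", "first", "only" and "open" are said of these compounds alone.

- Compound 1 `COC(=O)N1N=C(c2ccc(OC)cc2)CC1c1cc(OC)c(OC)c(OC)c1`: 2550 nM
- Compound 2 `CCOc1cccc(C2=NN(C(=O)OC)C(c3cc(OC)c(OC)c(OC)c3)C2)c1`: 4450 nM
- Compound 3 `COC(=O)N1N=C(c2ccc(OC)c(OC)c2)CC1c1cc(OC)c(OC)c(OC)c1`: not yet measured

These values come from a functional assay on HT-29 cells (Homo sapiens) for antiproliferative activity, read by MTT assay, with a stated time of 48 h; on this read-out higher numbers stand for weaker inhibition of growth and lower numbers for stronger inhibition of growth. Compound 2 gives 4450 nM, which lies within the usual scatter of compound 1 at 2550 nM, so the two cannot be told apart.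

Compound 3 carries 3,4-dimethoxyphenyl in place of 3-ethoxyphenyl on a carbon with a double bond to nitrogen. Going by the values given here, only one measured step changes the group at this place: a 1.7-fold higher number from compound 1 to compound 2 (0.24 log units; within the scatter). A single small step is thin evidence, but it gives no ground for expecting a large move in this assay, and no clear direction. The expected change is therefore none beyond the scatter, estimated as a 1.3-fold lower number from compound 2 to compound 3 (0.13 log units; within the scatter). For compound 3 the expected value is 3300 nM, with an estimated range of 1300 nM to 8000 nM.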

Compound 3, concentration for 50% growth inhibition: 9200 nM
Estimate against measurement, compound 3: 2.8-fold (0.45 log units) below, outside the stated range (above it).
By their numbers in this assay, from the lowest: compounds 1 and 2 (each within the scatter of the next); then compound 3.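

In this assay, going by these compounds alone, methoxy in place of hydrogen on an aromatic carbon of the 4-methoxyphenyl group gives a 3.6-fold higher number from compound 1 to compound 3 (0.56 log units; beyond the scatter) and so marks the first change at this position that clearly exceeds the scatter. The move from 3-ethoxyphenyl to 3,4-dimethoxyphenyl gives a 2.1-fold higher number from compound 2 to compound 3 (0.32 log units; beyond the scatter) and points the same way, so compound 3 is the weakest growth inhibitor of the three, although both steps are modest. This position therefore responds to the groups on the aromatic ring, but no measurement here explains that response.

On these data alone, what remains open is how a hydroxyl or an amine on this aromatic ring would behave. A longer chain, such as propoxy, in place of the ethoxy of 3-ethoxyphenyl also remains an open case.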